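The compounds below may be only part of what the source reports. "The series", "measured", "known", "first", "only" and "open" are said of these compounds alone.

Measured in a functional assay on HL-60 cells (Homo sapiens) for cytotoxicity, read by CCK-8 assay, with a stated time of 24 h (a higher number here means a weaker inhibitor, a lower number a stronger inhibitor), as half-maximal inhibitory concentrations:

Compound 1 `C=CC(=O)N1C(=O)CC(c2ccc(C)cc2)Sc2ccccc21` gives 94400 nM here
Compound 2 `C=CC(=O)N1C(=O)CC(c2ccc(OC)cc2)Sc2ccccc21` gives 92100 nM here
Compound 3 `C=CC(=O)N1C(=O)CCSc2ccccc21` gives 44800 nM here

Compound 3 has the lowest number of the three, and both other compounds stand above it by steps beyond the scatter. Compound 4 `C=CC(=O)N1C(=O)CC(c2cccc(Cl)c2)Sc2ccccc21` has not yet been measured. It differs from compound 3 by one change (3-chlorophenyl in place of hydrogen on a saturated ring carbon), with 3-chlorophenyl in place of hydrogen on a saturated ring carbon next to the ring sulfur.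

For the measured compounds named here, two measured steps bear on this, since both concern a substituted phenyl group at that same carbon. Removing 4-methylphenyl gives (a 2.1-fold lower number from compound 1 to compound 3 (0.32 log units; beyond the scatter)), and removing 4-methoxyphenyl gives (a 2.1-fold lower number from compound 2 to compound 3 (0.31 log units; beyond the scatter)). Both steps are modest, and the change to compound 4 runs the opposite way, so a modest rise in the number is expected in this assay for this change. The swap of methyl for methoxy (a 1.0-fold lower number from compound 1 to compound 2 (0.01 log units; within the scatter)) stayed within the scatter, but no chlorinated phenyl group has been measured, so the range is kept wide.

The expected step is (a 2.0-fold higher number from compound 3 to compound 4 (0.30 log units; within the scatter)). For compound 4 the estimate is 90000 nM as the middle value, with an expected range from 50000 nM to 160000 nM around it.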

Compound 4, half-maximal inhibitory concentration: 93100 nM
Beside the measured number, compound 4's estimate is 1.0-fold (0.01 log units) below it, and the stated range covers the measured number.
By their numbers in this assay, from the lowest: compound 3; then compounds 2, 4 and 1 (each within the scatter of the next).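

In this assay, the 3-chlorophenyl group on the saturated ring carbon next to the ring sulfur gives a step (a 2.1-fold higher number from compound 3 to compound 4 (0.32 log units; beyond the scatter)) that matches those seen with the two earlier substituted phenyl groups, so the rise now holds for a ring bearing chlorine as well as for rings bearing methyl or methoxy. Exchanging the phenyl groups themselves has no readable effect (a 1.0-fold higher number from compound 2 to compound 4 (0.00 log units; within the scatter); a 1.0-fold lower number from compound 1 to compound 4 (0.01 log units; within the scatter)), so compounds 1, 2 and 4 cannot be told apart here, although their substituents differ in both identity and ring position; among the four compounds, the only readable difference at this carbon is between hydrogen and a substituted phenyl group, and none goes against this. No measured evidence is available to explain this pattern.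

The compounds shown leave open whether a phenyl ring is needed for the rise, or whether a small alkyl group such as methyl, or a longer chain, at the same carbon would give the same step. They also leave open whether a substituted phenyl group carrying an amine or a carboxylic acid would stay level with compounds 1, 2 and 4.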